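A few compounds are considered here, and "the series" means these few. Any claim that something is new, unique, unknown or untested is made for them only; others in the source may bear on it.

Three compounds on a shared core have numbers in a functional assay on HepG2 cells (Homo sapiens) for antiproliferative activity, read by MTT assay, with a stated time of 48 h; on this read-out lower numbers stand for stronger inhibition and higher numbers for weaker inhibition. Compound 1 (`O=[N+]([O-])c1cc(C(F)(F)F)cc([N+](=O)[O-])c1Oc1ccccc1/C=N/OCc1ccc(Cl)cc1Cl`) gives 1020 nM, and compound 2 (`O=[N+]([O-])c1cc(C(F)(F)F)cc([N+](=O)[O-])c1Oc1ccc(Cl)cc1/C=N\OCc1ccccc1`) gives 1790 nM. Compound 3 (`O=[N+]([O-])c1cc(C(F)(F)F)cc([N+](=O)[O-])c1Oc1c(Cl)cc(Cl)cc1/C=N\OCc1ccccc1`) gives 1120 nM, which lies within the scatter of both other compounds, so it cannot be ranked against either.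

Compound 4 (`O=[N+]([O-])c1cc(C(F)(F)F)cc([N+](=O)[O-])c1Oc1c(Cl)cc(Cl)cc1/C=N/OCc1ccccc1Cl`) departs from compound 3 by one change: a group of 11 heavy atoms (8 carbon, 1 nitrogen, 1 oxygen, 1 chlorine; one six-membered aromatic ring of carbon only) in place of a group of 10 heavy atoms (8 carbon, 1 nitrogen, 1 oxygen; one six-membered aromatic ring of carbon only), on an aromatic carbon. The change sits ortho to a large group and meta to two chloro groups.

Within the data shown here, only one measured step bears on this change, and it is an indirect guide. It placed chloro in place of hydrogen on an aromatic carbon elsewhere in the molecule and amounted to a 1.6-fold lower number from compound 2 to compound 3 (0.20 log units; within the scatter). Compound 1, which also carries chloro groups on its outer ring, gives a similar 1020 nM. No step beyond the scatter is therefore expected in this assay.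

The expected change is a 1.1-fold lower number from compound 3 to compound 4 (0.05 log units; within the scatter). For compound 4 the estimated value is 1000 nM, with an expected range of 500 nM to 2000 nM.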

Compound 4, half-maximal inhibitory concentration: 1120 nM
Compound 4: middle estimate off by 1.1-fold (0.05 log units), on the low side, and the stated range covers the measured number.
By their numbers in this assay, from the lowest: compounds 1, 3, 4 and 2 (each within the scatter of the next).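

Replacing the chlorine-free group of compound 3 with the chlorine-bearing group of compound 4 gives no change at the digits printed from compound 3 to compound 4 (within the scatter) in this assay, so this place on the shared core accepts the larger group with no readable change. The earlier step had tested chloro in place of hydrogen only elsewhere in the molecule, whereas this one also carries a second difference, as the two structures are drawn with opposite geometry at the carbon-nitrogen double bond, and it reads both differences as one. No measurement offered here explains why the number stays where it does.

On these data alone, what the chlorine and the drawn geometry would each do alone remains open. So does whether an amine or a carboxylic acid on this ring would leave the number equally unchanged.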